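The source may hold more compounds than are shown below. What is called first, only, known or untested is meant among the compounds shown, and "the series" means these compounds.

Measured compounds:
compound 1 `O=C(CCCCC1CCSS1)NCc1cn(CCCCCOc2ccc3ccc(=O)oc3c2)nn1` gives 84.9%
compound 2 `Cc1cc(=O)oc2cc(OCCCCCn3cc(CNC(=O)CCCCC4CCSS4)nn3)ccc12` gives 73.7%

In a functional assay on PC-12 cells (Rattus norvegicus) for cytotoxicity, read by MTT assay, with stated times of 3 h and 2 h, tested at 50 uM (a lower number here means a weaker effect, a higher number a stronger effect of the compound at the concentration tested), compound 1 stands highest of the two measured numbers; the nearest is compound 2, where the step of a number 11.2 percentage points lower from compound 1 to compound 2 (beyond the scatter) lies beyond the scatter. Compound 3 `CC(=O)c1cc2ccc(OCCCCCn3cc(CNC(=O)CCCCC4CCSS4)nn3)cc2oc1=O` is not yet measured. It differs from compound 1 by acetyl in place of hydrogen on an aromatic carbon. Going by the values given here, the only measured step that bears on this is the one from methyl in place of hydrogen on an aromatic carbon, a number 11.2 percentage points lower from compound 1 to compound 2 (beyond the scatter), which was modest and downward; an acetyl is a different group at a different place on the core, so that step is only a loose guide. A step of similar size, downward, or none beyond the scatter, is therefore expected. For compound 3 the estimate is 76%, within 60% to 88%, meaning an expected step of a number 8.9 percentage points lower from compound 1 to compound 3 (within the scatter).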

Compound 3, a percentage reported as activity, at one concentration (the size of the read-out at that concentration, not a potency): 18.2%
Compound 3: middle estimate off by 57.8 percentage points, on the high side, outside the stated range (below it).
By their numbers in this assay, from the lowest: compound 3; then compound 2; then compound 1.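

In this assay the step of a number 66.7 percentage points lower from compound 1 to compound 3 (beyond the scatter) shows that this aromatic carbon, two atoms from the ring oxygen, does not tolerate every change: a small acetyl of 3 heavy atoms is enough to shift the read-out strongly. Going by these compounds alone, the only earlier step, a number 11.2 percentage points lower from compound 1 to compound 2 (beyond the scatter), came from a methyl at a different place and gave no sign that a single added group could move the number this far. Nothing available here explains the size of this drop.

Still open, on these data alone, is whether the drop belongs to the acetyl alone or would follow any group on this carbon, such as an amine, a carboxylic acid or an ethyl. A single compound also cannot show whether the same acetyl elsewhere on the shared core would give a similar step.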